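Working notes on the step to compound 3

This account rests on a few compounds, and the source may have more. Where it says the series, first, only, none or still open, it means among the compounds named here.

compound 1 `C=C(Br)C(=O)Nc1cccc(/C=C/C(=O)Nc2ccccc2)c1` gives 1100 nM
compound 2 `C=C(Br)C(=O)Nc1cccc(/C=C/C(=O)Nc2ccc(C)cc2)c1` gives 190 nM

In a functional assay on SEM cells (Homo sapiens) for inhibition, read by MTT assay, with a stated time of 72 h (a higher number here means a weaker inhibitor, a lower number a stronger inhibitor), compound 2 holds the lower of the two numbers. Compound 3 `C=C(Br)C(=O)Nc1cccc(/C=C/C(=O)Nc2ccc(OCC)cc2)c1` carries ethoxy in place of methyl on an aromatic carbon. Within the data shown here, the one measured step that bears on this is methyl in place of hydrogen on an aromatic carbon (a 5.8-fold lower number from compound 1 to compound 2 (0.76 log units; beyond the scatter)), modest and beyond the scatter. It gives no reading on ethoxy, so no step beyond the scatter is expected in this assay in either direction. The expected change is small (a 1.2-fold lower number from compound 2 to compound 3 (0.07 log units; within the scatter)). Compound 3 is estimated at 160 nM (expected range 50 nM to 500 nM).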

Compound 3, half-maximal inhibitory concentration: 180 nM
Estimate against measurement, compound 3: 1.1-fold (0.05 log units) below; the range from low to high includes it.
By their numbers in this assay, from the lowest: compounds 3 and 2 (each within the scatter of the next); then compound 1.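

In this assay, the aromatic carbon para to a large group takes ethoxy as readily as methyl: a 1.1-fold lower number from compound 2 to compound 3 (0.02 log units; within the scatter) stays within the scatter, despite the larger group and its added hydrogen-bond acceptor. The drop from hydrogen also recurs with a second group, a 6.1-fold lower number from compound 1 to compound 3 (0.79 log units; beyond the scatter), beyond the scatter. Nothing at hand explains either step. Still open, from the compounds shown here alone, is whether this level holds for an amine, a carboxylic acid or a longer alkoxy chain at this place. Going by these compounds, whether any such group would move beyond the scatter from compound 3 also remains open.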